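A few compounds are considered here, and "the series" means these few. Any claim that something is new, unique, unknown or untested is made for them only; others in the source may bear on it.

Measured so far:
- compound 1 `O=C(/C=C/c1ccco1)c1ccccc1OCC1CO1`: 48300 nM
- compound 2 `O=C(/C=C/c1ccco1)c1ccc(OCC2CO2)cc1`: 48900 nM

Both numbers are half-maximal inhibitory concentrations from a functional assay on MDA-MB-468 cells (Homo sapiens) for inhibition, read by CCK-8 assay and cell counting, with a stated time of 2 days; a higher number here means a weaker inhibitor, a lower number a stronger inhibitor. Compound 2, at 48900 nM, lies within the usual scatter of compound 1, so these two values cannot be put in any order. Within the data shown here, with only this pair, there is no measured step to learn from.

Compound 3 `O=C(/C=C/c1cccs1)c1ccc(OCC2CO2)cc1` has not yet been measured. It differs from compound 2 by a single swap: thiophen-2-yl in place of furan-2-yl on a double-bonded chain carbon bound to a double-bonded chain carbon. In words, this is thiophen-2-yl in place of furan-2-yl on a double-bonded chain carbon bound to a double-bonded chain carbon. Among the measured compounds shown here, the two groups match in size and in the kind of ring, and no measured pair shows what this swap does. In this assay, no step beyond the scatter is therefore expected, in either direction, and the value of compound 2, 48900 nM, serves as the anchor. The expected change is small: a 1.2-fold lower number from compound 2 to compound 3 (0.07 log units; within the scatter). For compound 3 the estimated value is 42000 nM, with an expected range from 18000 nM to 90000 nM.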

Compound 3, half-maximal inhibitory concentration: 17200 nM
Compound 3: middle estimate off by 2.4-fold (0.39 log units), on the high side, outside the stated range (below it).
By their numbers in this assay, from the lowest: compound 3; then compounds 1 and 2 (each within the scatter of the next).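

In this assay, among these compounds, thiophen-2-yl in place of furan-2-yl gives a 2.8-fold lower number from compound 2 to compound 3 (0.45 log units; beyond the scatter), the first measured step in this set. It shows that this place, on a double-bonded chain carbon bound to a double-bonded chain carbon, responds to a small change: the two groups have the same number of heavy atoms, the same kind of ring and the same hydrogen-bond counts, and differ in that sulfur replaces oxygen, yet the number moves beyond the scatter. The step is modest and rests on a single pair, so it describes this swap on the core of compound 2 and is not a general rule for the series. No measurement available here accounts for the difference between these two closely matched rings.

Among the compounds shown here, it remains open whether the same swap would lower the number on the core of compound 1, where the only value available is for the furan-2-yl form. On these data alone, it is also open how this place would respond to a six-membered ring such as phenyl or pyridin-2-yl, or to a thiophen-2-yl ring carrying an added amine or carboxylic acid.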